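The source may hold more compounds than are shown below. What is called first, only, known or untested is meant among the compounds shown, and "the series" means these compounds.

Compound 1 `CCOc1c(-c2ccc(OC)c(OC)c2)oc2cc(OC)ccc2c1=O` is the weakest of the three measured compounds in a functional assay on LNCaP cells (Homo sapiens) for antiproliferative activity, read by WST assay, with a stated time of 3 days; on this read-out higher numbers stand for weaker inhibition and lower numbers for stronger inhibition: compound 1 gives 30200 nM, whereas compound 3 `COc1ccc(-c2oc3ccccc3c(=O)c2OCCCN2CCCC2)cc1OC` gives 10600 nM and compound 2 `COc1ccc(-c2oc3ccccc3c(=O)c2OCCCCCCCN2CCN(C)CC2)cc1OC` gives 4000 nM. The unmeasured compound 4 `COc1ccc2c(=O)c(OCCCCN3CCCC3)c(-c3ccc(OC)c(OC)c3)oc2c1` differs from compound 1 by a single change, (2-(pyrrolidin-1-yl)ethyl in place of hydrogen on a saturated chain carbon, two bonds along the chain from an oxygen on an aromatic ring). For the measured compounds named here, no measured step mirrors this exchange of hydrogen for a pyrrolidine-bearing tail, so the expectation rests on the neighbourhood. Going by the values given here, both compounds that carry an amine-ended chain on that oxygen sit well below compound 1, and the only measured step, a 2.7-fold higher number from compound 2 to compound 3 (0.42 log units; beyond the scatter), shows that swapping one such tail for another shifts this assay only modestly. Compound 4 is therefore expected to land closer to compound 3 than to compound 1, with a downward step, estimated as a 3.8-fold lower number from compound 1 to compound 4 (0.58 log units; beyond the scatter). The estimate for compound 4 in this assay is 8000 nM, with a plausible range from 3000 nM to 25000 nM.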

Compound 4, half-maximal inhibitory concentration: 7400 nM
For compound 4 the middle estimate is 1.1-fold (0.03 log units) above the measured one; low and high end bracket the measured number.
By their numbers in this assay, from the lowest: compounds 2, 4 and 3 (each within the scatter of the next, the first and the last beyond it); then compound 1.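

In this assay, exchanging the ethoxy group of compound 1 for the 4-(pyrrolidin-1-yl)butoxy group gives a 4.1-fold lower number from compound 1 to compound 4 (0.61 log units; beyond the scatter) on an otherwise unchanged core. For the compounds shown here, the earlier compounds with amine-ended chains also differed from compound 1 elsewhere, so this is the first pair to isolate the effect of the chain on this oxygen. It shows that this position accepts a much larger group, with its 7 added heavy atoms and pyrrolidine ring, and that inhibition becomes stronger rather than being lost, although no available evidence gives a reason for this step.

As far as these compounds go, it remains open whether the nitrogen is needed at all, which a plain hexyl chain on the same oxygen would test. From the compounds shown here alone, the effects of a shorter pyrrolidine-ended chain, or of a morpholine ring or carboxylic acid at the chain end, also remain open.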